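A few compounds are considered here, and "the series" means these few. Any claim that something is new, unique, unknown or untested is made for them only; others in the source may bear on it.

In a functional assay on the whole organism (blood) with Rattus norvegicus as the target, with stated times of 24 h and 1 h, at a dose of 1 mg/kg by the intraperitoneal route (on this read-out lower numbers stand for a weaker effect and higher numbers for a stronger effect at the one dose given), three compounds built on one shared core have been measured. Compound 1 `O=C(NC1CCCCC1)NS(=O)(=O)N1CCC(CCNC(=O)c2cccc3cccnc23)CC1` gives 29% in this assay. Compound 2 `O=C(NC[C@@H]1C[C@@H]2C=C[C@@H]1C2)NS(=O)(=O)N1CCC(CCNC(=O)c2cccc3cccnc23)CC1` gives 32% in this assay. Compound 3 `O=C(NC1CCCCC1)NS(=O)(=O)N1CCC(CCNC(=O)c2cc(Cl)cc3cccnc23)CC1` gives 17% in this assay, which makes compound 3 the weakest of the three, since its steps to both others lie beyond the scatter.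

Compound 1 and compound 2 differ in one place: a group of 8 heavy atoms (8 carbon; 2 five-membered non-aromatic rings of carbon only) in place of a group of 6 heavy atoms (6 carbon; one six-membered non-aromatic ring of carbon only), on an amide-type nitrogen. That change made a step of a number 3 percentage points higher from compound 1 to compound 2 (within the scatter), so the two numbers cannot be ordered against each other. Compound 1 and compound 3 differ in their cores: chloro in place of hydrogen on an aromatic carbon. That change made a step of a number 12 percentage points lower from compound 1 to compound 3 (beyond the scatter).

Compound 4 `O=C(NC[C@@H]1C[C@@H]2C=C[C@@H]1C2)NS(=O)(=O)N1CCC(CCNC(=O)c2cc(Cl)cc3cccnc23)CC1` has not yet been measured in this assay. It stands to compound 3 exactly as compound 2 stands to compound 1. Within the data shown here, the change is a group of 8 heavy atoms (8 carbon; 2 five-membered non-aromatic rings of carbon only) in place of a group of 6 heavy atoms (6 carbon; one six-membered non-aromatic ring of carbon only), on an amide-type nitrogen, the same change as the one from compound 1 to compound 2, made here on the core of compound 3, which carries the chloro group. With a single earlier example of this change, and that example within the scatter, compound 4 is expected to sit close to compound 3, with an expected step of a number 3 percentage points higher from compound 3 to compound 4 (within the scatter). This rests on compound 3 giving 17% and on the earlier step of a number 3 percentage points higher from compound 1 to compound 2 (within the scatter). Compound 4 is therefore estimated at 20% in this assay, with a likely range from 8% to 33%.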

Compound 4, a percentage reported as activity, at one dose (the size of the read-out at that dose, not a potency): 16%
For compound 4 the middle estimate is 4 percentage points above the measured one; the measured number falls inside the stated range.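

In this assay, the exchange of cyclohexyl for the group of 8 heavy atoms on the amide-type nitrogen, made on the core that carries chloro, gave a step of a number 1 percentage points lower from compound 3 to compound 4 (within the scatter) and so repeated the outcome seen on the core without chloro: the same change on two cores in this assay, a number 3 percentage points higher (within the scatter) from compound 1 to compound 2 and a number 1 percentage points lower (within the scatter) from compound 3 to compound 4, 4 percentage points apart, within the scatter of two such steps. Chloro in place of hydrogen, made on the core that carries the group of 8 heavy atoms, gave a step of a number 16 percentage points lower from compound 2 to compound 4 (beyond the scatter) and so also repeated its earlier outcome: the same change on two cores in this assay, a number 12 percentage points lower (beyond the scatter) from compound 1 to compound 3 and a number 16 percentage points lower (beyond the scatter) from compound 2 to compound 4, 4 percentage points apart, within the scatter of two such steps. Across these four compounds, each change therefore carried from one core to the other, the chloro step staying beyond the scatter and the ring exchange staying within it, but this rests on only two cores per change and on a single dose, so it shows neither a general rule for the series nor anything about potency.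

The compounds shown leave open whether a bromo or methoxy group in place of chloro would give a step like that of chloro. They also leave open whether an open alkyl chain or a piperidine ring in place of cyclohexyl would stay as close to the cyclohexyl compounds as the group of 8 heavy atoms does.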